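One chlorine fewer on compound 3

The compounds below may be only part of what the source reports. "The series", "measured", "known", "first", "only" and "open" are said of these compounds alone.

Compound 1 `CC(=O)OC/C(=C\c1ccc(Cl)cc1Cl)C(=O)c1ccccc1` gives 97000 nM
Compound 2 `COc1ccc(C(=O)/C(=C/c2ccccc2F)COC(C)=O)cc1` gives 22500 nM
Compound 3 `COc1ccc(C(=O)/C(=C/c2ccc(Cl)cc2Cl)CCOC(C)=O)cc1` gives 69200 nM

In a functional assay on A549 cells (Homo sapiens) for inhibition, read by XTT assay, with a stated time of 48 h (on this read-out higher numbers stand for weaker inhibition and lower numbers for stronger inhibition), compound 3 gives 69200 nM and lies within the usual scatter of compound 1 at 97000 nM in this set of three, while compound 2 at 22500 nM stands clearly lower. Compound 4 `COc1ccc(C(=O)/C(=C/c2ccc(Cl)cc2)CCOC(C)=O)cc1` differs from compound 3 by hydrogen in place of chloro on an aromatic carbon and so has hydrogen in place of chloro on an aromatic carbon, turning 2,4-dichlorophenyl into 4-chlorophenyl. For the measured compounds named here, no measured pair isolates this change, so the expectation is no step beyond the scatter in this assay and at most a slight move towards a lower number. The expected step is small (a 1.4-fold lower number from compound 3 to compound 4 (0.14 log units; within the scatter)) and may prove to be none. For compound 4 the estimate is 50000 nM (expected range 20000 nM to 110000 nM).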

Compound 4, half-maximal inhibitory concentration: 86000 nM
The estimate for compound 4 lay 1.7-fold (0.24 log units) below the measured number; the measured number falls inside the stated range.
By their numbers in this assay, from the lowest: compound 2; then compounds 3, 4 and 1 (each within the scatter of the next).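

Turning 2,4-dichlorophenyl into 4-chlorophenyl gives a 1.2-fold higher number from compound 3 to compound 4 (0.09 log units; within the scatter) in this assay, and this is the first pair here that differs in only one place. At this aromatic carbon, then, chloro and hydrogen cannot be told apart in this assay. No measurement shown here offers an explanation for this result. Still open, going by these compounds, is whether an amine or a carboxylic acid on this same carbon would shift the number beyond the scatter. Also open, on these data alone, is what removing the remaining chloro group would do.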